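A few compounds are considered here, and "the series" means these few. Any claim that something is new, unique, unknown or untested is made for them only; others in the source may bear on it.

Measured so far:
compound 1 `C=c1[nH]c(=O)/c(=C/c2ccc3ccccc3c2)[nH]c1=O`; in a functional assay on Huh7.5.1 cells (Homo sapiens) for cytotoxicity, read by MTT assay, with a stated time of 72 h (on this read-out higher numbers stand for lower toxicity in this test and lower numbers for higher toxicity in this test), compound 1 gives > 20000 nM, which is a limit of the test rather than a number.
compound 2 `C=CC(C)(C)c1[nH]c2ccccc2c1/C=c1\[nH]c(=O)c(=C)[nH]c1=O`; in this assay compound 2 gives > 20000 nM, likewise a limit.

Compound 2 stands at the limit, as does every value shown here (the limit of > 20000 nM in this assay, at which 2 of the 2 values shown sit). Going by the values given here, no two measured compounds differ in one place, so no measured step is available for comparison, and the data give no direction at all.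

Compound 3 `C=c1[nH]c(=O)/c(=C/c2c[nH]c3ccccc23)[nH]c1=O` differs from compound 2 by hydrogen in place of 1,1-dimethylprop-2-en-1-yl on an aromatic carbon. With both measured compounds resting at the limit, the step expected in this assay is none beyond the usual scatter, and most probably another limit. Compound 3 is expected to give 30000 nM, with a range of 15000 nM to 80000 nM. This estimate means an expected step that the limit leaves unreadable from compound 2 to compound 3.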

Compound 3, half-maximal cytotoxic concentration: > 20000 nM
Compound 3: only a limit was reported; the forecaster's own chance of this, stated with the estimate: 80%; the middle value is on the limit's open side.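

No step can be read between compound 2 and compound 3, because both give a limit and not a number: the limit of > 20000 nM in this assay, at which 3 of the 3 values shown sit.

The compounds shown leave open whether 1,1-dimethylprop-2-en-1-yl or hydrogen on that aromatic carbon makes any difference in this assay, and at what concentration any of the three would turn toxic.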